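Swapping one halogenated phenyl ring for another on a shared core

The source may hold more compounds than are shown below. What is called first, only, known or untested is meant among the compounds shown, and "the series" means these compounds.

Compound 1, `CCOC(=O)c1c(-c2cc3ccccc3oc2=O)nn(-c2ccccc2)c1C(=O)OCC`: 100000 nM
Compound 2, `CCOC(=O)c1c(-c2cc3ccccc3oc2=O)nn(-c2cccc(F)c2)c1C(=O)OCC`: 59000 nM

Of the compounds shown here, two have been measured in a functional assay on A549 cells (Homo sapiens) for cytotoxicity, read by MTT assay, with a stated time of 48 h; on this read-out higher numbers stand for weaker inhibition and lower numbers for stronger inhibition. Compound 1 gives 100000 nM, and compound 2 gives 59000 nM. Among the compounds with values here, the only step between them, a 1.7-fold lower number from compound 1 to compound 2 (0.23 log units; within the scatter), is small, so compound 2 and compound 1 cannot be told apart on these numbers; both sit in the weak range of this assay.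

Compound 3, `CCOC(=O)c1c(-c2cc3ccccc3oc2=O)nn(-c2ccc(Br)cc2)c1C(=O)OCC`, is the next variation. Its difference from compound 2 is 4-bromophenyl in place of 3-fluorophenyl on an aromatic nitrogen. Within the data shown here, the single measured step that bears on this change is the one from compound 1 to compound 2, which also altered only the phenyl ring on the same aromatic nitrogen and stayed within the scatter. On that basis a step beyond the scatter in this assay is not expected in either direction for compound 3, and the step from compound 2 is estimated as a 1.2-fold lower number from compound 2 to compound 3 (0.07 log units; within the scatter). Compound 3 is therefore expected to give about 50000 nM in this assay, with a plausible range from 20000 nM to 150000 nM.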

Compound 3, half-maximal inhibitory concentration: 100000 nM
Compound 3: the middle estimate sits 2.0-fold (0.30 log units) below what was measured; measured number inside the range.
By their numbers in this assay, from the lowest: compounds 2, 1 and 3 (each within the scatter of the next).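

Replacing 3-fluorophenyl with 4-bromophenyl on the aromatic nitrogen gives a 1.7-fold higher number from compound 2 to compound 3 (0.23 log units; within the scatter) in this assay and adding bromo in place of hydrogen on the phenyl ring gives no change at the digits printed from compound 1 to compound 3 (within the scatter) in the same assay. Two different halogenated rings, 3-fluorophenyl and 4-bromophenyl, now both lie within the scatter of the plain phenyl ring of compound 1, so swapping the halogen and its place on the ring has not yet produced a step that can be told apart from repeated measurement, and all three compounds remain in the weak range. Nothing available here offers a reason for how closely these numbers agree.

The compounds shown carry only hydrogen, fluoro or bromo on this phenyl ring, so it remains open whether a group of another kind there, such as an amine, a carboxylic acid or a methoxy group, would give a step beyond the scatter. From the compounds shown here alone, it is also open whether changing a different part of the shared core, such as replacing an ethoxycarbonyl group with a carboxylic acid, would matter more than anything on this ring.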